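Trimming a Butyl Chain on a Receptor Antagonist

A few compounds are considered here, and "the series" means these few. Any claim that something is new, unique, unknown or untested is made for them only; others in the source may bear on it.

Going by the values given here, compound 1 `CCCCN(CC)c1nc(C)nc2c(-c3ccc(OC)nc3C)c(C)nn12` stands as the stronger of the two compounds measured so far. In an assay on cell membranes for displacement of a labelled ligand from corticotropin-releasing factor receptor 1 (Rattus norvegicus) (on this read-out lower numbers stand for stronger inhibition and higher numbers for weaker inhibition), compound 1 gives 4.9 nM. Among the compounds with values here, the only other measured compound, compound 2 `CCN(CC)c1nc(C)nc2c(-c3c(C)cc(N(C)C)nc3C)c(C)nn12`, differs from it in more than one place, so the two cannot be compared as a single step; in this assay compound 2 gives 58 nM, a weaker result. Compound 3 `CCN(CC)c1nc(C)nc2c(-c3ccc(OC)nc3C)c(C)nn12` has not yet been measured. It differs from compound 1 by one change: hydrogen in place of ethyl on a saturated chain carbon, two bonds along the chain from a nitrogen on an aromatic ring. Within the data shown here, no measured pair differs in exactly this way, so there is no direct precedent for the size of the step. The step of a 2.4-fold higher number from compound 1 to compound 3 (0.39 log units; beyond the scatter) is estimated as a small loss, beyond the usual scatter but not far beyond it. Compound 3 is therefore expected to give about 12 nM in this assay, within a range from 4 nM to 40 nM.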

Compound 3, half-maximal inhibitory concentration: 12 nM
For compound 3 middle estimate and measured number coincide at the digits printed; low and high end bracket the measured number.
By their numbers in this assay, from the lowest: compound 1; then compound 3; then compound 2.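

The change from butyl(ethyl)amino to diethylamino now has a measured size: in this assay the step is a 2.4-fold higher number from compound 1 to compound 3 (0.39 log units; beyond the scatter), a modest loss. Shortening the chain therefore weakens inhibition only slightly, and compound 3 still gives 12 nM, so the full butyl length is not needed for inhibition in the low nanomolar range. No measurement available here explains why the longer chain gives the lower number.

From the compounds shown here alone, it remains open how a propyl or pentyl chain would read at this position, or a cyclopropylmethyl group, or a ring amine such as morpholine in place of the whole butyl(ethyl)amino group. Also open, going by these compounds, is whether butyl in place of ethyl would bring a step of similar size on compound 2.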